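The compounds below may be only part of what the source reports. "The series", "measured", "known", "first", "only" and "open" are said of these compounds alone.

Going by the values given here, compound 2 `CC(C)c1noc(N2CCN(C(=O)[C@@H]3CCCN(S(=O)(=O)c4ccc(S(=O)(=O)NC(C)(C)C)cc4)C3)CC2)n1` gives 100 nM in a functional assay on MIA PaCa-2 cells (Homo sapiens) for inhibition, read by MTT assay, with a stated time of 3 days (on this read-out higher numbers stand for weaker inhibition and lower numbers for stronger inhibition), the lower of the two numbers measured so far. Among the compounds with values here, its only measured neighbour is compound 1 `CC(C)c1noc(N2CCN(C(=O)[C@@H]3CCCN(S(=O)(=O)c4ccc(S(=O)(=O)NC5CC5)cc4)C3)CC2)n1`, which in this assay gives 300 nM; the step of a 3.0-fold lower number from compound 1 to compound 2 (0.48 log units; beyond the scatter) came with tert-butyl in place of cyclopropyl on a sulfonamide nitrogen. Compound 3 `CC(C)c1noc(N2CCN(C(=O)[C@@H]3CCCN(S(=O)(=O)c4ccc(S(=O)(=O)C(C)C)cc4)C3)CC2)n1` alters the same sulfonyl group in a different way: isopropyl in place of (tert-butyl)amino on a sulfonyl sulfur. The sulfonamide nitrogen, with its hydrogen-bond donor, is gone and a plain isopropyl sits on the sulfonyl sulfur. Within the data shown here, no measured step mirrors this change; the single known step, from compound 1 to compound 2, only exchanged groups on that nitrogen and was modest. The expectation for compound 3 is therefore a small shift in this assay, leaning toward a higher number, with the step of a 2.0-fold higher number from compound 2 to compound 3 (0.30 log units; within the scatter) expected. Compound 3 is estimated at 200 nM, within 60 nM to 700 nM.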

Compound 3, half-maximal inhibitory concentration: 30 nM
For compound 3 the middle estimate is 6.7-fold (0.82 log units) above the measured one; measured number outside the range, below it.
By their numbers in this assay, from the lowest: compound 3; then compound 2; then compound 1.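

Putting isopropyl on the sulfonyl sulfur in place of (tert-butyl)amino gives a 3.3-fold lower number from compound 2 to compound 3 (0.52 log units; beyond the scatter), and putting it in place of cyclopropylamino gives a 10-fold lower number from compound 1 to compound 3 (1.00 log units; beyond the scatter). Going by these compounds alone, the earlier pair showed only that the group on the sulfonamide nitrogen could be exchanged; these steps show that in this assay activity at this position does not depend on keeping that nitrogen and its hydrogen-bond donor, since the isopropyl compound has the lowest number of the three. No measurement on hand accounts for the drop in the number.

The compounds shown leave open whether the gain comes from losing the nitrogen or from the isopropyl group itself. A methyl or ethyl on the sulfonyl sulfur, or a plain amino group there, would help separate these two readings.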